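The source may report more compounds than this note shows. Statements on the series, on what has been measured and on what is new or still open speak of the compounds shown alone.

Compound 2 `CSCC[C@H](NC(=O)CN(c1nc(Cl)nc2[nH]cnc12)C1CC1)C(=O)OCc1ccccc1` and compound 1 `CC[C@H](C)[C@H](NC(=O)CN(c1nc(Cl)nc2[nH]cnc12)C1CC1)C(=O)OCc1ccccc1` share the same core and differ only at one saturated chain carbon. In a functional assay on the whole organism (Tail, strain ICR) with Mus musculus as the target, in the tail flick test, with a stated time of 90 min, at a dose of 25 umol/kg by the oral route (a higher number here means a stronger effect of the compound at the dose given, a lower number a weaker effect), compound 2 gives 44.6%, and compound 1 gives 36.3%; the step of a number 8.3 percentage points higher from compound 1 to compound 2 (within the scatter) lies within the scatter, so the two compounds stand level and neither can be called the stronger. Compound 3 `CC(C)C[C@H](NC(=O)CN(c1nc(Cl)nc2[nH]cnc12)C1CC1)C(=O)OCc1ccccc1` is the next member, not yet measured. Its difference from compound 2 is isopropyl in place of (methylsulfanyl)methyl on a saturated chain carbon, two bonds along the chain from an amide-type nitrogen and a carbonyl carbon. Among the measured compounds shown here, only one measured step bears on this: the exchange from compound 1 to compound 2, which is also a swap of one neutral chain for another at the same region, and it was a number 8.3 percentage points higher from compound 1 to compound 2 (within the scatter). On that basis no step beyond the scatter is expected for compound 3 in this assay, and the expected change is a number 4.6 percentage points lower from compound 2 to compound 3 (within the scatter). Compound 3 is therefore estimated at 40%, with a range from 20% to 60%.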

Compound 3, a percentage reported as activity, at one dose (the size of the read-out at that dose, not a potency): 15.2%
Estimate against measurement, compound 3: 24.8 percentage points above; measured number below the stated range.
By their numbers in this assay, from the lowest: compound 3; then compounds 1 and 2 (each within the scatter of the next).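

In this assay, the side chain at this position is not interchangeable among neutral groups: a number 29.4 percentage points lower from compound 2 to compound 3 (beyond the scatter), and a number 21.1 percentage points lower from compound 1 to compound 3 (beyond the scatter), whereas the earlier exchange between compound 1 and compound 2 stayed within the scatter. Compound 1 carries no sulfur yet stands level with compound 2, so losing the sulfur does not by itself track the lower read-out of compound 3, and the step from compound 1 to compound 3 shows that isobutyl and sec-butyl, both without sulfur, are not equivalent here. No measurement available here accounts for the difference between these chains.

The compounds shown leave open how a chain bearing an amine, a carboxylic acid or a phenyl ring would fare at this position. They also leave open whether these differences hold at other doses, since each read-out comes from a single dose and time.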